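Selenium for sulfur on a furan-amide acylimidothioate core

This account rests on a few compounds, and the source may have more. Where it says the series, first, only, none or still open, it means among the compounds named here.

Three acyl-substituted imidoyl compounds have been tested in a functional assay on PC-3 cells (Homo sapiens) for cytotoxicity, read by MTT assay, with a stated time of 72 h; a lower number here means a stronger inhibitor of growth, a higher number a weaker inhibitor of growth. Compound 1, `CS/C(=N\C(=O)c1ccco1)NC(=O)c1ccco1`, carries two furan carbonyl groups on a methylsulfanyl-bearing carbon with a double bond to nitrogen; in this assay compound 1 gives 56200 nM. Compound 3, `CS/C(=N\C(=O)c1cc(-c2ccccc2)nc2ccccc12)NC(=O)c1cc(-c2ccccc2)nc2ccccc12`, keeps that methylsulfanyl centre but bears a different core, and in this assay compound 3 gives 7480 nM. The difference between the two cores is not broken down here. Compound 2, `O=C(/N=C(/NC(=O)c1cc(-c2ccccc2)nc2ccccc12)[Se]Cc1ccccc1)c1cc(-c2ccccc2)nc2ccccc12`, shares the core of compound 3, and in this assay compound 2 gives 39300 nM.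

The change from compound 3 to compound 2 is a group of 8 heavy atoms (7 carbon, 1 selenium; one six-membered aromatic ring of carbon only) in place of a group of 2 heavy atoms (1 carbon, 1 sulfur; no ring), on a carbon with a double bond to nitrogen. That change made the number move by a 5.3-fold higher number from compound 3 to compound 2 (0.72 log units; beyond the scatter). Compound 1 stands highest of the three numbers, within the scatter of compound 2 and beyond it from compound 3.

Compound 4, `O=C(/N=C(/NC(=O)c1ccco1)[Se]Cc1ccccc1)c1ccco1`, has not yet been measured. Its relation to compound 1 is a group of 8 heavy atoms (7 carbon, 1 selenium; one six-membered aromatic ring of carbon only) in place of a group of 2 heavy atoms (1 carbon, 1 sulfur; no ring), on a carbon with a double bond to nitrogen, the same change as from compound 3 to compound 2, at a place described in the same words. For the measured compounds named here, only that one earlier example is available, and it rests on a different core, so the transfer is uncertain. The step from compound 1 to compound 4 is expected to be a 2.7-fold higher number from compound 1 to compound 4 (0.43 log units; beyond the scatter), on the assumption that the change seen in a 5.3-fold higher number from compound 3 to compound 2 (0.72 log units; beyond the scatter) carries over. Compound 4 is therefore estimated at 150000 nM, with a range from 50000 nM to 400000 nM, and there is a real chance that this assay reports only a limit for compound 4.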

Compound 4, concentration for 50% growth inhibition: 30500 nM
Beside the measured number, compound 4's estimate is 4.9-fold (0.69 log units) above it; the measured number lies below the stated range.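

On the core of compound 1, putting the selenium-bearing group with its six-membered aromatic ring in place of methylsulfanyl gives, in this assay, a 1.8-fold lower number from compound 1 to compound 4 (0.27 log units; within the scatter), a step that cannot be told apart from no change at all. Set beside the earlier step, the same change did not carry over from one core to the other in this series: the same change on two cores in this assay, a 5.3-fold higher number (0.72 log units; beyond the scatter) from compound 3 to compound 2 and a 1.8-fold lower number (0.27 log units; within the scatter) from compound 1 to compound 4, 9.7-fold (0.99 log units) apart, beyond the scatter of two such steps. This shows that, for these two pairs, the result of the change on one core could not be used to read its result on the other, but two pairs do not show what in the cores lies behind the gap, give no rule for a further core, and cannot separate the selenium from the added ring, since both enter together.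

The compounds shown leave open how a methylselanyl group or a benzylsulfanyl group would read on either core, and either one would help to divide the change into its two parts. Also open, going by these compounds, is whether an amine or a longer chain, placed on the carbon with a double bond to nitrogen, would give matching steps on the two cores.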